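The compounds below may be only part of what the source reports. "The series", "measured", "known", "first", "only" and "open" are said of these compounds alone.

Compound 1 `CC[C@@H](CCn1cncn1)c1ccc(Cl)cc1`: in an ADME assay on HEp-2 cells (Homo sapiens) for cytotoxicity, read by MTT assay, with a stated time of 3 days (a higher number here means that more compound is tolerated, a lower number that less compound is tolerated), compound 1 gives 55.1 ug/mL.
Compound 2 `CC[C@@H](CCn1cncn1)c1ccc(C)cc1`: in this assay compound 2 gives 69.9 ug/mL.
Compound 3 `CC[C@@H](CCn1cncn1)c1ccc(OC)cc1`: in this assay compound 3 gives 146 ug/mL.

Compound 1 carries the lowest number of the three. Its step of a 1.3-fold higher number from compound 1 to compound 2 (0.10 log units; within the scatter) lies within the scatter, whereas a 2.6-fold higher number from compound 1 to compound 3 (0.42 log units; beyond the scatter) and a 2.1-fold higher number from compound 2 to compound 3 (0.32 log units; beyond the scatter) lie beyond it. Compound 4 `CCC[C@@H](CCn1cncn1)c1ccc(Cl)cc1` differs from compound 1 by methyl in place of hydrogen on a saturated chain carbon, three bonds along the chain from an aromatic carbon. For the measured compounds named here, every measured step replaces one substituent on the aromatic ring by another; none touches the saturated chain, so no measured step bears directly on this change. Lacking such a guide, the expected step in this assay is none beyond the scatter. Compound 4 is therefore estimated at 50 ug/mL, between 25 ug/mL and 110 ug/mL, which means an expected step of a 1.1-fold lower number from compound 1 to compound 4 (0.04 log units; within the scatter).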

Compound 4, half-maximal cytotoxic concentration: 36.6 ug/mL
For compound 4 the middle estimate is 1.4-fold (0.14 log units) above the measured one; the measured number falls inside the stated range.
By their numbers in this assay, from the lowest: compounds 4, 1 and 2 (each within the scatter of the next); then compound 3.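

Compound 4 is the first of these compounds changed on the saturated chain rather than on the aromatic ring. In this assay methyl in place of hydrogen gives a 1.5-fold lower number from compound 1 to compound 4 (0.18 log units; within the scatter) and so this chain carbon takes the added methyl without a step beyond the scatter. No evidence given here explains this result. The compounds shown leave open whether a longer chain, an amine or a carboxylic acid at this carbon would also stay within the scatter of compound 1. From the compounds shown here alone, whether the methoxy of compound 3 keeps its step alongside this chain also remains open.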